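Mirror-image step from compound 3 to compound 4

The compounds below may be only part of what the source reports. "The series", "measured", "known", "first", "only" and "open" are said of these compounds alone.

Measured in an ADME assay on the whole organism with Oryza sativa as the target, tested at 10 uM; on this read-out higher numbers stand for a weaker effect at the one concentration tested and lower numbers for a stronger effect:
Compound 1, `C[C@H](NC(=O)Nc1ccc(F)cc1)c1ccccc1`, gives 85%.
Compound 2, `C[C@H](NC(=O)Nc1ccc(F)cc1F)c1ccccc1`, gives 99%.
Compound 3, `Cc1cc(F)ccc1NC(=O)N[C@H](C)c1ccccc1`, gives 94%.

Compound 3 holds the second highest of the three numbers; its gaps to compound 2 and to compound 1 both lie within the scatter. Among the compounds with values here, the only measured step is a number 14 percentage points higher from compound 1 to compound 2 (beyond the scatter), and it concerns a fluoro group, not configuration, so it does not bear on the present change. Compound 4, `Cc1cc(F)ccc1NC(=O)N[C@@H](C)c1ccccc1`, differs from compound 3 thus: the two compounds have the same atoms and bonds and differ only in configuration as drawn: 1 of 1 stereo elements differ; a stereocentre at a saturated chain carbon is drawn R in compound 3 and S in compound 4. Within the data shown here, the data hold no step in which only configuration changes. The expected step is therefore a number 4 percentage points lower from compound 3 to compound 4 (within the scatter), none beyond the scatter. Compound 4 is estimated at 90%, within a range of 70% to 100%.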

Compound 4, a percentage reported as activity, at one concentration (the size of the read-out at that concentration, not a potency): 96%
Estimate against measurement, compound 4: 6 percentage points below; low and high end bracket the measured number.
By their numbers in this assay, from the lowest: compounds 1, 3, 4 and 2 (each within the scatter of the next, the first and the last beyond it).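

In this assay, the change of configuration alone gives a number 2 percentage points higher from compound 3 to compound 4 (within the scatter), so at this saturated chain carbon, drawing S in place of R produces no difference that can be told from the scatter, and the comparison isolates that single change: the fact that compounds 3 and 4 differ only in the configuration as drawn With the same configuration drawn, methyl in place of fluoro on an aromatic carbon gives a number 3 percentage points lower from compound 2 to compound 4 (within the scatter). Swapping a hydrogen on an aromatic carbon for methyl gives a number 11 percentage points higher from compound 1 to compound 4 (beyond the scatter).

The compounds shown leave open whether configuration stays this silent with a methoxy or chloro group on that aromatic carbon. They also leave open what an amine on the chain would do.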